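The source may report more compounds than this note shows. Statements on the series, on what has been measured and on what is new or still open speak of the compounds shown alone.

Compound 2 `CCCCCOC(=O)N1CCN(C(=O)[C@H](CCC(=O)O)NC(=O)c2cc(N3CCC(COC)CC3)nc(-c3ccccc3)n2)CC1` carries a methoxymethyl group on a saturated ring carbon of its piperidine. In an ADME assay on microsomes from liver (Homo sapiens) for metabolic stability (on this read-out higher numbers stand for a more stable compound and lower numbers for a less stable compound), compound 2 gives > 80%, which is a limit of the assay rather than a number. Compound 1 `CCCCCOC(=O)N1CCN(C(=O)[C@H](CCC(=O)O)NC(=O)c2cc(N3CCC(C(=O)N(CC)CC)CC3)nc(-c3ccccc3)n2)CC1` bears a diethylcarbamoyl group at the same spot. In this assay compound 1 gives > 80%, again a limit. The step that the two limits leave unreadable from compound 1 to compound 2 is therefore not readable in size. Compound 3 `CCCCCOC(=O)N1CCN(C(=O)[C@H](CCC(=O)O)NC(=O)c2nc(-c3ccccc3)cc(N3CCC(COC)CC3)n2)CC1` differs from compound 2 in the arrangement of the shared core. In this assay compound 3 gives > 80%, also a limit. All three values sit at the limit of > 80% in this assay, at which 3 of the 3 values shown sit.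

Compound 4 `CCCCCOC(=O)N1CCN(C(=O)[C@H](CCC(=O)O)NC(=O)c2cc(N3CCC(C(N)=O)CC3)nc(-c3ccccc3)n2)CC1` has not yet been measured. It differs from compound 2 by carbamoyl in place of methoxymethyl on a saturated ring carbon. For the measured compounds named here, the only measured step at this position, from compound 1 to compound 2, could not be read, so no size of change is known for a swap at this carbon. With every neighbour sitting at the limit, compound 4 is expected to show a step that the limit leaves unreadable from compound 2 to compound 4, nothing beyond the scatter. For compound 4 the estimate in this assay is 88%, with a range from 72% to 100%.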

Compound 4, percent of the compound remaining: > 80%
Compound 4: a limit, no number; the forecaster's own chance of this, stated with the estimate: 80%; the middle value lies beyond the limit too.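

In this assay compound 4 gives > 80%, a limit and not a number, so the steps to it from compound 1 and compound 2 cannot be read. The compounds shown leave open whether diethylcarbamoyl, methoxymethyl and carbamoyl on this ring carbon differ at all in this assay.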